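Methoxy in Place of Methyl on a Chain Near Nitrogen

This account rests on a few compounds, and the source may have more. Where it says the series, first, only, none or still open, it means among the compounds named here.

Measured so far in an assay on cell membranes for displacement of a labelled ligand from adenosine receptor A1 (Rattus norvegicus); on this read-out lower numbers stand for stronger inhibition and higher numbers for weaker inhibition:
compound 1 `CCn1c(=O)c2c(nc(Cc3ccccc3)n2C)n(Cc2ccco2)c1=O` gives 28.8 nM;
compound 2 `CCCn1c(=O)c2c(nc(Cc3ccccc3)n2C)n(Cc2ccco2)c1=O` gives 26.9 nM;
compound 3 `CCCn1c(=O)c2c(nc(Cc3ccco3)n2C)n(Cc2ccco2)c1=O` gives 132 nM.

Compound 2 has the lowest number of the three, but compound 1 sits within the usual scatter of it, as the step of a 1.1-fold lower number from compound 1 to compound 2 (0.03 log units; within the scatter) shows, so the two cannot be ranked against each other. Compound 3 is the only one clearly apart, and the step of a 4.9-fold higher number from compound 2 to compound 3 (0.69 log units; beyond the scatter) is modest but beyond the scatter; that step concerns a different part of the molecule, the benzyl-type group on the shared core, not the chain on the aromatic nitrogen.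

Compound 4 `COCCn1c(=O)c2c(nc(Cc3ccccc3)n2C)n(Cc2ccco2)c1=O` is not yet measured. Compared with compound 2 the change is methoxy in place of methyl on a saturated chain carbon, two bonds along the chain from an aromatic nitrogen. Among the compounds with values here, the one step that bears on this place is the lengthening from compound 1 to compound 2, which stayed within the scatter, suggesting this chain tolerates small changes at its end. The step to compound 3 does not touch this position and gives no guidance here. A step in this assay within or close to the scatter is therefore expected, with a slight lean toward a higher number; the expected step is a 1.3-fold higher number from compound 2 to compound 4 (0.13 log units; within the scatter). Compound 4 is estimated at 36 nM, within a range from 15 nM to 90 nM.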

Compound 4, inhibition constant: 174 nM
Compound 4: middle estimate off by 4.8-fold (0.68 log units), on the low side; measured number outside the range, above it.
By their numbers in this assay, from the lowest: compounds 2 and 1 (each within the scatter of the next); then compounds 3 and 4 (each within the scatter of the next).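

In this assay this chain end proves less forgiving than the earlier pair suggested: the ethyl of compound 1 and the propyl of compound 2 could not be told apart, yet putting methoxy in place of the end methyl of the propyl chain brings a 6.5-fold higher number from compound 2 to compound 4 (0.81 log units; beyond the scatter) and so moves the number beyond the scatter. Within the data shown here, the comparison with the shorter chain points the same way, with a 6.0-fold higher number from compound 1 to compound 4 (0.78 log units; beyond the scatter) on going from ethyl to 2-methoxyethyl, so both reference compounds separate from the methoxy compound by a modest step, and lengthening the chain by itself, the only change the first pair tested, says little about what a methoxy end will do. Nothing measured on these compounds accounts for the rise, so the reason for it remains unknown.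

A butyl chain, a 2-hydroxyethyl chain or a 2-aminoethyl chain on the same nitrogen would help show whether the rise goes with the oxygen of the methoxy or with other kinds of chain end as well. On these data alone, it also stays open whether a 2-methoxyethyl chain would bring a step of similar size when furan-2-yl stands in place of phenyl.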